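Ether side chain on the shared core: compound 3 to compound 4

This account rests on a few compounds, and the source may have more. Where it says the series, first, only, none or still open, it means among the compounds named here.

Three compounds share the core of compound 1 `COCC1=CS(=O)(=O)c2ccccc2C1=O` and differ only in the ether side chain. In a functional assay on the whole organism for inhibition, with Mus musculus as the target, at a dose of 10 mg/kg (a lower number here means less inhibition, a higher number more inhibition at the dose given (going by the name of the read-out)), compound 1 gives 99.9%. Compound 2 `O=C1C(COCCBr)=CS(=O)(=O)c2ccccc21` gives 100%, and compound 3 `O=C1C(COCCCl)=CS(=O)(=O)c2ccccc21` gives 98.1%. Compound 3 holds the smallest of the three numbers, but the gaps are covered by the scatter: a number 1.8 percentage points lower from compound 1 to compound 3 (within the scatter) and a number 1.9 percentage points lower from compound 2 to compound 3 (within the scatter). Compound 4 `COCCOCC1=CS(=O)(=O)c2ccccc2C1=O` differs from compound 3 by methoxy in place of chloro on a saturated chain carbon, two bonds along the chain from an oxygen on a saturated carbon. The step of a number 1.9 percentage points lower from compound 2 to compound 3 (within the scatter) changes the same position and is flat, as is a number 0.1 percentage points higher from compound 1 to compound 2 (within the scatter); every variation of this chain so far leaves this assay near its ceiling. Compound 4 is therefore expected to show a number 1.1 percentage points lower from compound 3 to compound 4 (within the scatter), no step beyond the scatter. The estimate for compound 4 is 97%, with a range from 85% to 100%.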

Compound 4, a percentage reported as inhibition, in the whole organism at one dose (the size of the read-out at that dose, not a potency): 98.2%
Compound 4: the middle estimate sits 1.2 percentage points below what was measured; low and high end bracket the measured number.
By their numbers in this assay, from the lowest: compounds 3, 4, 1 and 2 (each within the scatter of the next).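

Methoxy brings one hydrogen-bond acceptor where chloro has none, yet this assay shows a number 0.1 percentage points higher from compound 3 to compound 4 (within the scatter) at this position. The comparison with bromo gives a number 1.8 percentage points lower from compound 2 to compound 4 (within the scatter) and the comparison with the unextended ether gives a number 1.7 percentage points lower from compound 1 to compound 4 (within the scatter), so a chain ending in an oxygen group stays as flat as the halogen-ended chains. No measurement at hand accounts for this flatness. As far as these compounds go, whether an amine or a carboxylic acid at the chain end, or a longer chain, would leave the number near its ceiling stays open.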